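Thiophene for Cyclopropyl at the Imidazoline Amine Side Chain

The source may report more compounds than this note shows. Statements on the series, on what has been measured and on what is new or still open speak of the compounds shown alone.

Measured compounds:
Compound 1, `Brc1cccc(Br)c1N(CC1CC1)C1=NCCN1`, gives -1.12 in a physicochemical assay for lipophilicity; on this read-out lower numbers stand for lower lipophilicity and higher numbers for higher lipophilicity.
Compound 2, `Brc1cccc(Br)c1N(CC1CCCC1)C1=NCCN1`, gives 0.32 in this assay.

Going by the values given here, compound 1 stands at the lower of the two numbers; the only neighbour is compound 2, reached by a number 1.44 log units higher from compound 1 to compound 2 (beyond the scatter), a large step beyond the scatter. The new compound 3, `Brc1cccc(Br)c1N(Cc1cccs1)C1=NCCN1`, changes compound 1 as follows: thiophen-2-yl in place of cyclopropyl on a saturated chain carbon bound to a nitrogen on an aromatic ring. Among the compounds with values here, the one measured step bears on this only loosely, since it swaps one saturated ring for a larger saturated ring, while here a five-membered aromatic ring with 1 hetero atom enters. Still, that step shows that a larger group on this carbon can move this assay upward by a wide margin. A rise is therefore expected, smaller than for compound 2, as a number 1.02 log units higher from compound 1 to compound 3 (beyond the scatter). Compound 3 is estimated at -0.1, expected between -0.8 and 0.6.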

Compound 3, distribution coefficient: -0.1
Compound 3: middle estimate and measured number agree at the digits printed; measured number inside the range.
By their numbers in this assay, from the lowest: compound 1; then compound 3; then compound 2.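

The position takes more than saturated rings: in this assay, thiophen-2-yl on this chain carbon also lifts the number by a wide margin (a number 1.02 log units higher from compound 1 to compound 3 (beyond the scatter)). The size of the new group does not settle the outcome on its own, since replacing cyclopentyl with thiophen-2-yl gives a smaller but still clear change (a number 0.42 log units lower from compound 2 to compound 3 (beyond the scatter)), leaving compound 3 in the middle of the series. No supporting measurements are available to explain why these steps differ in size.

The compounds shown leave open how a phenyl ring, a furan-2-yl ring, thiophen-3-yl or a longer chain ending in an amine would behave on this carbon. As far as these compounds go, all three compounds share the same core, so whether these steps would carry over to another core also remains open.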